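The source may report more compounds than this note shows. Statements on the series, on what has been measured and on what is new or still open speak of the compounds shown alone.

Of the compounds shown here, two on the shared core have been tested so far. In a functional assay on K562 cells (Homo sapiens) for cytotoxicity, read by MTT assay, with a stated time of 48 h (a lower number here means a stronger inhibitor, a higher number a weaker inhibitor), compound 1 `NC(=O)CC[C@H](NS(=O)(=O)c1ccc([N+](=O)[O-])cc1)C(=O)O` gives > 500000 nM, which is a limit of the assay and not a number. Going by the values given here, compound 2 `CC(C)NC(=O)CC[C@H](NS(=O)(=O)c1ccc([N+](=O)[O-])cc1)C(=O)O` gives 19800 nM, the only true number so far. The next compound, compound 3 `CCCCNC(=O)CC[C@H](NS(=O)(=O)c1ccc([N+](=O)[O-])cc1)C(=O)O`, differs from it by butyl in place of isopropyl on an amide-type nitrogen. Among the compounds with values here, only one measured step bears on that nitrogen, and there a hydrogen gave way to isopropyl. Since compound 2 already carries a group at this place, the change in this assay is expected to be much smaller than the one measured, an at least 25-fold lower number from compound 1 to compound 2 (1.40 log units; beyond the scatter). The expected step is a 1.3-fold lower number from compound 2 to compound 3 (0.12 log units; within the scatter), which would not lie beyond the scatter. For compound 3 the estimated value is 15000 nM, with an expected range of 6000 nM to 40000 nM.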

Compound 3, half-maximal inhibitory concentration: 19700 nM
Compound 3: middle estimate off by 1.3-fold (0.12 log units), on the low side, within the range that was stated.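

Exchanging isopropyl for butyl on the amide-type nitrogen gives a 1.0-fold lower number from compound 2 to compound 3 (0.00 log units; within the scatter) in this assay so the two groups cannot be told apart at this place. Going by these compounds alone, the earlier compounds showed only that one group, isopropyl, differs from hydrogen on this nitrogen; butyl now gives an at least 25-fold lower number from compound 1 to compound 3 (1.40 log units; beyond the scatter) as well, so the drop does not belong to isopropyl alone. From the compounds shown here alone, the size of that step stays open-ended because compound 1 stands at a limit and not at a number: the limit of > 500000 nM in this assay, at which 1 of the 3 values shown sits.

The compounds shown leave open whether a longer chain such as octyl on this nitrogen would carry the value beyond the scatter from compound 2. They also leave open what a benzyl group, or a chain ending in an amine or a carboxylic acid, would do there.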